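Series notes: cytotoxicity in J774 cells, outlook for compound 4

The source may hold more compounds than are shown below. What is called first, only, known or untested is meant among the compounds shown, and "the series" means these compounds.

Measured so far:
compound 1 `O=S(=O)(Nc1cccc(CO)c1)c1ccc(-c2ccc3cc[nH]c3c2)cc1` gives 2500 nM
compound 2 `CN(c1cccc(CO)c1)S(=O)(=O)c1ccc(-c2ccc(Cl)cc2Cl)cc1` gives 2200 nM
compound 3 `O=C(Nc1cccc(CO)c1)c1ccc(-c2ccc(F)cc2F)cc1` gives > 15000 nM (a limit of the assay, not a number)

In a functional assay on J774 cells (Mus musculus) for cytotoxicity, read by resazurin assay, with a stated time of 72 h (a higher number here means a weaker inhibitor, a lower number a stronger inhibitor), compound 1 stands at the higher of the two numbers reported, with compound 2 lying within the scatter of it, so no order between the two is claimed. Compound 3 sits only at the limit of the assay (the limit of > 15000 nM in this assay, at which 1 of the 3 values shown sits). The unmeasured compound 4 `O=S(=O)(Nc1cccc(CO)c1)c1ccc(-c2ccc(Cl)cc2)cc1` differs from compound 1 in one place: 4-chlorophenyl in place of 1H-indol-6-yl on an aromatic carbon. Among the compounds with values here, no step between two measured compounds isolates this change. The closest comparison is compound 2, which also carries a chlorinated phenyl ring on the shared core, though with a methylated sulfonamide, and its value lies beside that of compound 1. The step from compound 1 to compound 4 is expected to be small, toward a weaker inhibitor if anything, a 1.4-fold higher number from compound 1 to compound 4 (0.15 log units; within the scatter). Compound 4 is estimated at 3500 nM, with a range from 1200 nM to 10000 nM.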

Compound 4, half-maximal inhibitory concentration: 2500 nM
For compound 4 the middle estimate is 1.4-fold (0.15 log units) above the measured one; the range from low to high includes it.
By their numbers in this assay, from the lowest: compounds 2, 1 and 4 (each within the scatter of the next). At a limit, above all of these: compound 3.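

In this assay, 4-chlorophenyl in place of 1H-indol-6-yl on an aromatic carbon, para to a large group, gives no change at the digits printed from compound 1 to compound 4 (within the scatter) on the shared core. The earlier compounds shown here held no step at this position; this one shows that the five-membered aromatic ring and its hydrogen-bond donor can leave, and a chlorine-bearing phenyl ring enter, with the number staying within the scatter. Nothing shown bears on the reason for this result.

Open, from the compounds shown here alone, is whether an amine or a carboxylic acid on the same aromatic carbon, in place of the 4-chlorophenyl, would move the number in this assay beyond the scatter. One step also cannot show whether this change would read the same with a different link within the shared core.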